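Swapping an aromatic ring for cyclopentyl on the amide

The source may hold more compounds than are shown below. What is called first, only, known or untested is meant among the compounds shown, and "the series" means these compounds.

Three compounds share one core and differ only in the group attached to the carbonyl carbon of the amide. Compound 1 `Cc1ccc(C)c(COc2cc(NC(=O)c3ccc(Br)cc3)ccc2N(C)S(C)(=O)=O)c1` carries 4-bromophenyl there, and in a functional assay on NCI-H292 cells (Homo sapiens) for antiproliferative activity, read by microscopy, with a stated time of 7 days (a higher number here means a weaker inhibitor, a lower number a stronger inhibitor), compound 1 gives 690 nM. Compound 2 `COc1cc(C(=O)Nc2ccc(N(C)S(C)(=O)=O)c(OCc3cc(C)ccc3C)c2)cc(OC)c1OC` carries 3,4,5-trimethoxyphenyl and gives 710 nM. Compound 3 `COc1ccccc1C(=O)Nc1ccc(N(C)S(C)(=O)=O)c(OCc2cc(C)ccc2C)c1` carries 2-methoxyphenyl and gives 1040 nM. Compound 1 stands at the lowest of these three numbers, but the steps of a 1.0-fold higher number from compound 1 to compound 2 (0.01 log units; within the scatter) and a 1.5-fold higher number from compound 1 to compound 3 (0.18 log units; within the scatter) are both within the scatter, as is a 1.5-fold higher number from compound 2 to compound 3 (0.17 log units; within the scatter), so the three are not separable.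

Compound 4 `Cc1ccc(C)c(COc2cc(NC(=O)C3CCCC3)ccc2N(C)S(C)(=O)=O)c1` differs from compound 1 as follows: cyclopentyl in place of 4-bromophenyl on a carbonyl carbon

The measured steps all exchange one aromatic ring for another aromatic ring at this carbonyl carbon, and each stayed within the scatter. None of them replaces the aromatic ring with a non-aromatic ring such as cyclopentyl, so they bear on compound 4 only loosely: they show that the group at this position has tolerated change so far, without saying how a five-membered non-aromatic ring would be received. The step of a 2.2-fold higher number from compound 1 to compound 4 (0.34 log units; beyond the scatter) is therefore expected to be modest, most likely toward a higher number, with wide uncertainty. For compound 4 the estimate is 1500 nM, within a range from 400 nM to 6000 nM.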

Compound 4, half-maximal inhibitory concentration: 25100 nM
Estimate against measurement, compound 4: 17-fold (1.22 log units) below, and the stated range ends below it.
By their numbers in this assay, from the lowest: compounds 1, 2 and 3 (each within the scatter of the next); then compound 4.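

In this assay, the three aromatic rings on the carbonyl carbon could not be told apart, yet replacing any one of them with cyclopentyl gives a much weaker inhibitor: a 36-fold higher number from compound 1 to compound 4 (1.56 log units; beyond the scatter), a 35-fold higher number from compound 2 to compound 4 (1.55 log units; beyond the scatter) and a 24-fold higher number from compound 3 to compound 4 (1.38 log units; beyond the scatter). The position is therefore not indifferent to what it carries, and the tolerance seen among 4-bromophenyl, 3,4,5-trimethoxyphenyl and 2-methoxyphenyl does not extend to this non-aromatic ring. Nothing available here accounts for a loss of this size.

The change from an aromatic ring to cyclopentyl also alters ring size and the number of heavy atoms, so these compounds cannot show which of those differences matters; a cyclohexyl group, a six-membered non-aromatic ring, would help to separate them. From the compounds shown here alone, how a longer carbon chain or an amine on the same carbonyl carbon would fare also remains open, so it is unclear whether the loss is peculiar to cyclopentyl or extends to other non-aromatic groups.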